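This account rests on a few compounds, and the source may have more. Where it says the series, first, only, none or still open, it means among the compounds named here.

Among the compounds with values here, compound 2 `CCCc1nc(-c2ccccc2)c(CNCCN2CCN(c3ccc(OC)cc3)CC2)o1` is one of two compounds so far measured in an assay on HEK293 cells for inhibition of Voltage-dependent T-type calcium channel subunit alpha-1G (Homo sapiens), read by fluorescence, tested at 10 uM (a lower number here means less inhibition, a higher number more inhibition at the concentration tested (going by the name of the read-out)), and in that assay compound 2 gives 51.5%. Its only companion, compound 1 `CCCc1nc(-c2ccccc2)c(CNCCN2CCN(c3cccc(OC)c3)CC2)o1`, gives 40.2% in this assay, so compound 2 stands highest of the two, the step being a number 11.3 percentage points higher from compound 1 to compound 2 (beyond the scatter). A third compound, compound 3 `CCCc1nc(-c2ccccc2)c(CNCCN2CCN(c3ccccc3C)CC2)o1`, awaits measurement in this assay. It differs from compound 2 in one place: 2-methylphenyl in place of 4-methoxyphenyl on an amine nitrogen in a ring.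

Within the data shown here, the single measured step bears on this change only loosely. Going from compound 1 to compound 2 exchanged a 3-methoxyphenyl for a 4-methoxyphenyl on the same ring nitrogen and raised inhibition modestly, a number 11.3 percentage points higher from compound 1 to compound 2 (beyond the scatter). The change to compound 3 is different in kind: the methoxy group is removed altogether and a 2-methylphenyl takes its place. Among the measured compounds shown here, with no measured example of such a swap, the expectation can only be that compound 3 falls somewhere near the two measured values, perhaps somewhat below compound 2. For compound 3 the estimated value in this assay is 42%, within a range of 22% to 62%, which corresponds to an expected step of a number 9.5 percentage points lower from compound 2 to compound 3 (within the scatter).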

Compound 3, a percentage reported as inhibition, at one concentration (the size of the read-out at that concentration, not a potency): 51.3%
Beside the measured number, compound 3's estimate is 9.3 percentage points below it; the measured number falls inside the stated range.
By their numbers in this assay, from the lowest: compound 1; then compounds 3 and 2 (each within the scatter of the next).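

In this assay, replacing the 4-methoxyphenyl with a 2-methylphenyl on the amine nitrogen in the ring gives a number 0.2 percentage points lower from compound 2 to compound 3 (within the scatter), so the two groups cannot be told apart here, and the methoxy oxygen of compound 2 is not needed to reach this level of inhibition. The same 2-methylphenyl, set against the 3-methoxyphenyl, gives a number 11.1 percentage points higher from compound 1 to compound 3 (beyond the scatter), which leaves compound 1 as the lowest of the three and shows that the earlier gap was not specific to the 4-methoxyphenyl. Nothing available explains why the 3-methoxyphenyl compound stands apart from the other two.

The step from compound 2 to compound 3 alters both the kind of group and where it sits on the phenyl ring, so a 2-methoxyphenyl or a 4-methylphenyl would be needed to separate those two effects. Going by these compounds, whether an unsubstituted phenyl, a 4-chlorophenyl or a benzyl would fit this nitrogen equally well stays open, as does how these readings at a single concentration relate to potency.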